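From vinyl to bromo in a small compound

This account rests on a few compounds, and the source may have more. Where it says the series, first, only, none or still open, it means among the compounds named here.

- Compound 1 `Brc1nc2ccccc2[se]1` gives > 40000 nM (a limit)
- Compound 2 `C=Cc1nc2ccccc2n1C` gives 9500 nM
- Compound 3 `C#CCNC(=O)c1cscn1` gives > 40000 nM (a limit)

Among the measured compounds shown here, in a functional assay on HCT-116 cells (Homo sapiens) for cytotoxicity, with a stated time of 3 days (on this read-out higher numbers stand for weaker inhibition and lower numbers for stronger inhibition), compound 2 gives the only true number, while the others rest at the limit of > 40000 nM in this assay, at which 2 of the 3 values shown sit, and show no number. Compound 4 `Cn1c(Br)nc2ccccc21` carries bromo in place of vinyl on an aromatic carbon and awaits measurement. For the measured compounds named here, no measured pair shows this swap, so only a modest move towards weaker inhibition is expected in this assay here. Compound 1 also carries bromo and its > 40000 nM is a limit, the only hint for that direction. The estimated step of a 2.1-fold higher number from compound 2 to compound 4 (0.32 log units; beyond the scatter) stays modest. For compound 4 the expected value is 20000 nM (estimated range 8000 nM to 50000 nM).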

Compound 4, half-maximal inhibitory concentration: > 40000 nM
Compound 4 was reported as a limit (the forecaster's own chance of this, stated with the estimate: 45%); middle value at least 2.0-fold (0.30 log units) away from the limit.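

In this assay, bromo in place of vinyl on this aromatic carbon, between two ring nitrogen atoms, gives an at least 4.2-fold higher number from compound 2 to compound 4 (0.62 log units; beyond the scatter). Among the compounds shown here, this is the first direct measure of a change at this position, and it shows that the cytotoxic effect of compound 2 does not survive this swap within the measurable range. The true size of the step stays unknown because compound 4 reached a limit: the limit of > 40000 nM in this assay, at which 3 of the 4 values shown sit.

The compounds shown leave open how an amine, an ethyl group or a longer chain at this carbon would compare with vinyl.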